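From compound 2 to compound 3: a new aryl group

This account rests on a few compounds, and the source may have more. Where it says the series, first, only, none or still open, it means among the compounds named here.

Compound 1 `CCS(=O)(=O)Nc1cc(-c2ccc3ncnc(Nc4ccc(F)cc4)c3c2)cnc1OC` gives 3160 nM
Compound 2 `CCS(=O)(=O)Nc1cc(-c2ccc3ncnc(Nc4ccc(Cl)c(C(=O)OC)c4)c3c2)cnc1OC` gives 3130 nM

Going by the values given here, in a functional assay on HCT-116 cells (Homo sapiens) for cytotoxicity, read by sulforhodamine B assay, with a stated time of 72 h (on this read-out higher numbers stand for weaker inhibition and lower numbers for stronger inhibition), compound 2 stands level with compound 1, the only other measured compound. Compound 3 `CCS(=O)(=O)Nc1cc(-c2ccc3ncnc(Nc4ccc(OC)nc4)c3c2)cnc1OC` differs from compound 2 at one place (6-methoxypyridin-3-yl in place of 4-chloro-3-(methoxycarbonyl)phenyl on a nitrogen on an aromatic ring), with 6-methoxypyridin-3-yl in place of 4-chloro-3-(methoxycarbonyl)phenyl on a nitrogen on an aromatic ring. Among the compounds with values here, one measured step bears on this, an exchange on that same nitrogen (a 1.0-fold lower number from compound 1 to compound 2 (0.00 log units; within the scatter)), so no step beyond the scatter is expected in this assay. The expected step is small (a 1.0-fold lower number from compound 2 to compound 3 (0.02 log units; within the scatter)). The estimated value for compound 3 is 3000 nM (range 900 nM to 10000 nM).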

Compound 3, half-maximal inhibitory concentration: 6910 nM
The estimate for compound 3 lay 2.3-fold (0.36 log units) below the measured number; low and high end bracket the measured number.
By their numbers in this assay, from the lowest: compounds 2 and 1 (each within the scatter of the next); then compound 3.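

In this assay the aryl group on the nitrogen turns out not to be indifferent: 6-methoxypyridin-3-yl gives a 2.2-fold higher number from compound 2 to compound 3 (0.34 log units; beyond the scatter) and likewise a 2.2-fold higher number from compound 1 to compound 3 (0.34 log units; beyond the scatter) as modest steps beyond the scatter, whereas 4-fluorophenyl and 4-chloro-3-(methoxycarbonyl)phenyl stood level. Going by these compounds alone, of the three groups, only the one with a hetero atom in its ring separates from the others. Nothing at hand explains this step.

From the compounds shown here alone, it stays open whether the ring nitrogen or the methoxy group goes with the higher number. Plain pyridin-3-yl or 4-methoxyphenyl on the same nitrogen would separate the two.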